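A few compounds are considered here, and "the series" means these few. Any claim that something is new, unique, unknown or untested is made for them only; others in the source may bear on it.

Three ureas built on the same core, compound 1 `CC(=O)c1ccc(NC(=O)Nc2cc(C)nc3ccccc23)cc1`, compound 2 `Cc1cc(NC(=O)Nc2cccc([N+](=O)[O-])c2)c2ccccc2n1` and compound 3 `Cc1cc(NC(=O)Nc2cccc3nsnc23)c2ccccc2n1`, were examined in an ADME assay on Raji cells (Homo sapiens) for cytotoxicity, with a stated time of 72 h; on this read-out higher numbers stand for an effect only at larger amounts of compound and lower numbers for an effect already at smaller amounts. In this assay compound 1 gives > 25000 nM, which is a limit of the assay and not a number. Compound 2 likewise reaches only a limit, > 25000 nM. Compound 3 also sits at a limit, > 25000 nM. Compound 2 therefore stands exactly where the whole set stands, namely at the limit of > 25000 nM in this assay, at which 3 of the 3 values shown sit, and no measured value separates it from either companion. Within the data shown here, with every measured value a limit, no step between measured compounds can be reckoned, and nothing in the measured set points to a direction of change.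

Compound 4 `Cc1cc(NC(=O)Nc2cccc(Cl)c2)c2ccccc2n1` differs from compound 2 in a single place: chloro in place of nitro on an aromatic carbon. Because compound 2 sits at the limit of > 25000 nM in this assay, at which 3 of the 3 values shown sit, the step from compound 2 to compound 4 is expected to be a step that the limit leaves unreadable from compound 2 to compound 4, which amounts to no change beyond the usual scatter. Compound 4 is expected to give about 30000 nM in this assay, with a range from 10000 nM to 100000 nM, and it is most likely that the assay will again report only a limit for it rather than a number.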

Compound 4, half-maximal effective concentration: 18000 nM
The estimate for compound 4 lay 1.7-fold (0.22 log units) above the measured number; the range from low to high includes it.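

Among these compounds, compound 4 is the first of the four compounds to give a number rather than a limit in this assay, which shows that this read-out can be reached when chloro stands in place of nitro on this aromatic carbon, meta to a large group. The size of the change can be stated only as a floor, an at least 1.3-fold lower number from compound 2 to compound 4 (0.14 log units; that floor lies within the scatter), so the data do not establish a shift beyond the usual scatter. The true size of the step stays unknown because compound 2 gives no number of its own: the limit of > 25000 nM in this assay, at which 3 of the 4 values shown sit.

The compounds shown leave open whether other groups on this aromatic carbon, such as an amine, a methoxy group or a carboxylic acid, would also give a number, and how far such numbers would lie from that of compound 4. They also leave open whether chloro would give a number on another carbon of the same ring, and compound 1 and compound 3 offer no comparison on this point, since each differs from compound 4 in more than one place.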